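A few compounds are considered here, and "the series" means these few. Any claim that something is new, unique, unknown or untested is made for them only; others in the source may bear on it.

Series notes. Compound 1 `COc1ccc(C(=O)CSc2nc3[nH]c(=O)n(C)c(=O)c3[nH]2)cc1` and compound 2 `Cn1c(=O)[nH]c2nc(SCC(=O)c3ccc(Cl)cc3)[nH]c2c1=O` share one core and differ at a single point. In a functional assay on A549 cells (Homo sapiens) for inhibition, read by MTT assay, with a stated time of 48 h (a higher number here means a weaker inhibitor, a lower number a stronger inhibitor), compound 1 gives 6100 nM, and compound 2 gives 8100 nM. The change between them, (chloro in place of methoxy on an aromatic carbon), made a step of a 1.3-fold higher number from compound 1 to compound 2 (0.12 log units; within the scatter), so the two values are not separated by the measurement.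

Compound 3 `COc1ccc(/C(CSc2nc3[nH]c(=O)n(C)c(=O)c3[nH]2)=N\O)cc1` carries a different core. In this assay compound 3 gives 1500 nM, the lowest of the three numbers and beyond the scatter from both compound 1 and compound 2. The difference between the core of compound 3 and the core of compound 1 is not broken down here.

Compound 4 `Cn1c(=O)[nH]c2nc(SC/C(=N/O)c3ccc(Cl)cc3)[nH]c2c1=O` has not been measured. It differs from compound 3 by chloro in place of methoxy on an aromatic carbon, which is the same change that separates compound 2 from compound 1, at the same place. Among the measured compounds shown here, only that one earlier step is available for this change, and it stayed within the scatter on the core of compound 1. Nothing in the set suggests the core of compound 3 would respond differently, so for compound 4 a step of about a 1.3-fold higher number from compound 3 to compound 4 (0.12 log units; within the scatter) is expected in this assay, resting on a 1.3-fold higher number from compound 1 to compound 2 (0.12 log units; within the scatter). Compound 4 is accordingly estimated at 2000 nM in this assay, with a likely range of 1000 nM to 4500 nM.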

Compound 4, half-maximal inhibitory concentration: 1890 nM
Beside the measured number, compound 4's estimate is 1.1-fold (0.02 log units) above it; the measured number falls inside the stated range.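

Working notes on the swap. In this assay, chloro in place of methoxy on an aromatic carbon, read cut one bond further out as 4-methoxyphenyl to 4-chlorophenyl, gives a step of a 1.3-fold higher number from compound 3 to compound 4 (0.10 log units; within the scatter) on the core of compound 3. Set against the earlier step on the core of compound 1, the change carries across the two cores without a detectable difference: the same change on two cores in this assay, a 1.3-fold higher number (0.12 log units; within the scatter) from compound 1 to compound 2 and a 1.3-fold higher number (0.10 log units; within the scatter) from compound 3 to compound 4, 1.1-fold (0.02 log units) apart, within the scatter of two such steps. Among the compounds shown here, this shows only that the swap stayed within the scatter on both cores in this one assay; with two pairs and two small steps, it does not show that a larger step would carry in the same way, that other substituents would behave alike, or that further cores would follow.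

Methoxy and chloro are the only groups shown at this place on the six-membered aromatic ring, so the response to an amine, a carboxylic acid or a longer chain there remains open. Also open, going by these compounds, is whether the same agreement between cores would hold for any of these groups, or for a longer chain in place of the methyl group on the shared core.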